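From compound 2 to compound 3: an aromatic ring leaves

The compounds below may be only part of what the source reports. "The series", "measured", "known", "first", "only" and "open" are said of these compounds alone.

Of the compounds shown here, two have numbers so far in a physicochemical assay for solubility, measured as kinetic solubility; a lower number here means a less soluble compound, a higher number a more soluble compound. Compound 1 (`Cc1cc(C)c(CN2CCc3c(Cl)cc([C@H](CO)[C@H]4CCOC4)c(Cl)c3C2=O)c(=O)[nH]1`) gives 570000 nM, and compound 2 (`COc1cc(C)[nH]c(=O)c1CN1CCc2c(Cl)cc(-c3c(C)noc3C)c(Cl)c2C1=O`) gives 384000 nM. These two values lie within the scatter of each other, so the available numbers do not separate compound 2 from compound 1. Among the measured compounds shown here, the two structures differ in more than one place, so they offer no clean step.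

Compound 3 (`COc1cc(C)[nH]c(=O)c1CN1CCc2c(Cl)cc([C@H](O)C3COC3)c(Cl)c2C1=O`) is still unmeasured. It departs from compound 2 in one place: a group of 6 heavy atoms (4 carbon, 2 oxygen; one four-membered non-aromatic ring with 1 hetero atom) in place of a group of 7 heavy atoms (5 carbon, 1 nitrogen, 1 oxygen; one five-membered aromatic ring with 2 hetero atoms), on an aromatic carbon. That carbon is ortho to a chloro group and meta to a chloro group. For the measured compounds named here, no measured pair isolates this exchange, so the expectation rests on little. Going by the values given here, the only guide is compound 1, which also lacks the 3,5-dimethyl-1,2-oxazol-4-yl group and gives 570000 nM. In this assay a small upward move is expected, probably none beyond the scatter. The estimated step is a 1.2-fold higher number from compound 2 to compound 3 (0.09 log units; within the scatter). For compound 3 the estimated value is 470000 nM, with an expected range from 230000 nM to 900000 nM.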

Compound 3, solubility: 234000 nM
The estimate for compound 3 lay 2.0-fold (0.30 log units) above the measured number; low and high end bracket the measured number.
By their numbers in this assay, from the lowest: compounds 3, 2 and 1 (each within the scatter of the next, the first and the last beyond it).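

In this assay, among the compounds shown here, this is the first clean step, and it concerns the aromatic carbon ortho to a chloro group and meta to a chloro group: exchanging the 3,5-dimethyl-1,2-oxazol-4-yl group for the group carrying a four-membered non-aromatic ring gives a 1.6-fold lower number from compound 2 to compound 3 (0.22 log units; within the scatter). Within this one pair, an aromatic ring at this position is therefore not required for a reading in the same range, and the exchange, which also brings in a hydrogen-bond donor and a defined stereocentre, does not separate compound 3 from compound 2 in this assay. Nothing available bears on why the two compounds read as they do, and a single pair sets no trend for the position.

From the compounds shown here alone, it remains open whether an amine, a carboxylic acid or a longer chain on this aromatic carbon would give a step beyond the scatter in this assay. The opposite configuration at the defined stereocentre of compound 3 is also not among the compounds shown, so the contribution of that centre remains unknown.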